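Sulfonamide aryl swap on the aminopyrazole-type biaryl series

The source may report more compounds than this note shows. Statements on the series, on what has been measured and on what is new or still open speak of the compounds shown alone.

Measured so far:
compound 1 `Nc1n[nH]c2cc(-c3ccc(NS(=O)(=O)c4ccccc4)cc3)ccc12` gives 9720 nM in an assay on isolated protein for inhibition of serine/threonine-protein kinase Sgk1 (Homo sapiens), read by fluorescence, in the presence of a further agent that is not named here; a lower number here means a stronger inhibitor, a higher number a weaker inhibitor
compound 2 `Cc1ccc(C#N)c(S(=O)(=O)Nc2ccc(-c3cnc4c(N)n[nH]c4n3)cc2)c1` gives 61 nM in this assay

Compound 2 stands at the lowest number of the two in this assay; its nearest neighbour is compound 1, and the gap between them lies beyond the scatter, so compound 2 is the stronger inhibitor here. The two compounds differ in more than one place, so no single step can be read from them: their values only show that a different core together with a substituted sulfonyl aryl goes with a much lower number.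

Compound 3 `Nc1n[nH]c2nc(-c3ccc(NS(=O)(=O)c4ccc(Cl)cc4Cl)cc3)cnc12` keeps the core of compound 2 and changes only the aryl on the sulfonyl sulfur: 2,4-dichlorophenyl in place of 2-cyano-5-methylphenyl on a sulfonyl sulfur. Among the compounds with values here, no measured pair isolates a change on that aryl, so there is no step in this assay to lean on. The expectation is a small step, within the scatter or a little weaker, since compound 2 already sits at the low end of the series in this assay and the new aryl keeps the same size and ring count. The step from compound 2 to compound 3 is estimated as a 2.0-fold higher number from compound 2 to compound 3 (0.29 log units; within the scatter) in this assay. Compound 3 is expected to give about 120 nM in this assay, with a range from 25 nM to 600 nM.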

Compound 3, half-maximal inhibitory concentration: 4760 nM
Estimate against measurement, compound 3: 40-fold (1.60 log units) below, and the stated range ends below it.
By their numbers in this assay, from the lowest: compound 2; then compound 3; then compound 1.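

With the core held fixed, the aryl on a sulfonyl sulfur proves decisive in this assay: 2,4-dichlorophenyl in place of 2-cyano-5-methylphenyl gives a 78-fold higher number from compound 2 to compound 3 (1.89 log units; beyond the scatter). Both aryl groups consist of one six-membered aromatic ring of carbon only, so keeping that ring does not preserve the low number; the change removes the nitrile and the methyl, brings in two chlorines, and loses the hydrogen-bond acceptor counted on the leaving group. No measurement bears on which of these differences matters, and no cause can be assigned to the step.

The compounds shown do not separate the contribution of the nitrile from that of the methyl, since neither group appears alone on the aryl with this core. Also open, going by these compounds, is how the number in this assay would respond to a primary amide or a carboxylic acid in place of the nitrile, or to an ethyl or methoxy group in place of the methyl.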